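Anilide series against Rho kinase: methyl to tolyl amide

This account rests on a few compounds, and the source may have more. Where it says the series, first, only, none or still open, it means among the compounds named here.

Within the data shown here, compound 2 `CC(=O)Nc1cccc(NC(=O)COc2ccc3c(=O)ccoc3c2)c1` gives 136 nM in an assay on isolated protein for inhibition of Rho-associated protein kinase 2 (Homo sapiens), read by scintillation counting, radiometric assay and 33P incorporation, with a stated time of 40 min, in the presence of a further agent that is not named here (a lower number here means a stronger inhibitor, a higher number a weaker inhibitor), the lowest of the two numbers so far; compound 1 `COc1cc(OCC(=O)Nc2cccc(NC(=O)c3ccc(N(C)C)cc3)c2)ccc1C=O` gives 306 nM in this assay, a gap beyond the usual scatter, though the two share no single-point difference. Compound 3 `Cc1ccc(C(=O)Nc2cccc(NC(=O)COc3ccc4c(=O)ccoc4c3)c2)cc1` differs from compound 2 in one place: 4-methylphenyl in place of methyl on a carbonyl carbon. Among the measured compounds shown here, no measured pair covers this change, so the expectation rests on compound 2 alone. The step is expected to be small, at most a slight weakening, within or near the scatter: a 1.3-fold higher number from compound 2 to compound 3 (0.12 log units; within the scatter). Compound 3 is therefore expected to give about 180 nM in this assay, between 60 nM and 550 nM.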

Compound 3, half-maximal inhibitory concentration: 22 nM
Beside the measured number, compound 3's estimate is 8.2-fold (0.91 log units) above it; measured number below the stated range.
By their numbers in this assay, from the lowest: compound 3; then compound 2; then compound 1.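

On the carbonyl carbon whose other neighbour is the amide-type nitrogen, the change from methyl to 4-methylphenyl gives a 6.2-fold lower number from compound 2 to compound 3 (0.79 log units; beyond the scatter) in this assay. This position therefore takes a group of 7 heavy atoms with one six-membered aromatic ring, and the stronger inhibition comes without any added hydrogen-bond donor or acceptor. Nothing at hand explains the gain.

On these data alone, whether it depends on the aromatic ring or on the methyl it carries remains open. Phenyl or cyclohexyl on the same carbonyl carbon would separate the two.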